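Methyl on the urea nitrogen of compound 3

The compounds below may be only part of what the source reports. "The series", "measured", "known", "first", "only" and "open" are said of these compounds alone.

In an assay (Cavia porcellus) for inhibition of Polyunsaturated fatty acid 5-lipoxygenase (Homo sapiens) (a higher number here means a weaker inhibitor, a lower number a stronger inhibitor), compound 1 `NC(=O)N(O)CC1COc2ccccc2O1` gives 15000 nM. Two changes to it were measured. Compound 2 `O=C(NCc1ccccc1)N(O)CC1COc2ccccc2O1` carries a benzyl group on the amide-type nitrogen, and in this assay compound 2 gives 2900 nM; that is a 5.2-fold lower number from compound 1 to compound 2 (0.71 log units; beyond the scatter). Compound 3 `NC(=O)N(O)CC1COc2cc(Oc3ccccc3)ccc2O1` carries a phenoxy group on an aromatic carbon instead, and in this assay compound 3 gives 450 nM; that is a 33-fold lower number from compound 1 to compound 3 (1.52 log units; beyond the scatter). Compound 3 therefore stands at the lowest number of the three, and its gap to compound 2 as well as to compound 1 is beyond the scatter.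

Compound 4 `CNC(=O)N(O)CC1COc2cc(Oc3ccccc3)ccc2O1` keeps the phenoxy group of compound 3 and adds a small change: methyl in place of hydrogen on an amide-type nitrogen. Going by the values given here, the only measured step that bears on this is the one from compound 1 to compound 2, where a benzyl group on the same nitrogen gave a 5.2-fold lower number from compound 1 to compound 2 (0.71 log units; beyond the scatter). Among the compounds with values here, a methyl group is much smaller than a benzyl group, and no measured pair shows what a methyl group alone does there, so the expected step is weaker. For compound 4 the expected step is a 1.5-fold lower number from compound 3 to compound 4 (0.18 log units; within the scatter), at most a modest lowering that may stay within the scatter. The estimate for compound 4 in this assay is therefore 300 nM, with a range from 100 nM to 900 nM.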

Compound 4, half-maximal inhibitory concentration: 420 nM
The estimate for compound 4 lay 1.4-fold (0.15 log units) below the measured number, within the range that was stated.
By their numbers in this assay, from the lowest: compounds 4 and 3 (each within the scatter of the next); then compound 2; then compound 1.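

In this assay, methyl in place of hydrogen on the amide-type nitrogen gives a 1.1-fold lower number from compound 3 to compound 4 (0.03 log units; within the scatter), so the amide hydrogen of compound 3 can be replaced by this one carbon without a change beyond the scatter. The lowering seen earlier with benzyl on this nitrogen, a 5.2-fold lower number from compound 1 to compound 2 (0.71 log units; beyond the scatter), does not appear with methyl on the phenoxy-bearing compounds. Nothing available explains why this step is so small.

The compounds shown leave open what benzyl itself would do on this nitrogen of compound 3, and so whether the difference between the two steps follows from the group that enters or from the presence of the phenoxy group. They also leave open whether an ethyl group, a longer chain or a chain ending in an amine would behave like methyl here.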